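The source may hold more compounds than are shown below. What is called first, only, known or untested is meant among the compounds shown, and "the series" means these compounds.

Compound 1, `O=S(=O)(c1ccc(F)c(Cl)c1)c1cnc2cc(F)ccc2c1-c1ccc(F)cc1`, and compound 2, `O=S(=O)(c1cc(Cl)cc(Cl)c1)c1cnc2cc(F)ccc2c1-c1ccc(F)cc1`, share one core and differ only in the ring carried on the sulfonyl sulfur. Within the data shown here, in an ADME assay on microsomes from liver (Homo sapiens) for metabolic stability, tested at 2.5 uM (on this read-out lower numbers stand for slow clearance and higher numbers for fast clearance), compound 1 gives 0.69 mL/min, while compound 2 gives 0.18 mL/min, the lowest of the two numbers known here; the change between them brought a 3.8-fold lower number from compound 1 to compound 2 (0.58 log units; beyond the scatter). Compound 3, `O=S(=O)(c1ccc(F)cc1)c1cnc2cc(F)ccc2c1-c1ccc(F)cc1`, is the next step from compound 2: 4-fluorophenyl in place of 3,5-dichlorophenyl on a sulfonyl sulfur. Among the measured compounds shown here, only the step from compound 1 to compound 2 bears on this, and it showed that exchanging the ring on the sulfonyl sulfur can move the number in this assay by a modest amount, beyond the scatter. Since the ring that enters in compound 3 carries fluorine rather than chlorine, as compound 1 partly did, the number is expected to rise again. The estimate for compound 3 is 0.6 mL/min, within 0.25 mL/min to 1.5 mL/min, which would mean a 3.3-fold higher number from compound 2 to compound 3 (0.52 log units; beyond the scatter).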

Compound 3, intrinsic clearance in a liver preparation (reported as CLH), per the amount of preparation that the assay uses: 1.34 mL/min
The estimate for compound 3 lay 2.2-fold (0.35 log units) below the measured number, and the stated range covers the measured number.
By their numbers in this assay, from the lowest: compound 2; then compounds 1 and 3 (each within the scatter of the next).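

In this assay, replacing 3,5-dichlorophenyl on the sulfonyl sulfur with 4-fluorophenyl brought a 7.4-fold higher number from compound 2 to compound 3 (0.87 log units; beyond the scatter) and so reversed the low number of compound 2. Putting hydrogen in place of chloro on an aromatic carbon brought a 1.9-fold higher number from compound 1 to compound 3 (0.29 log units; within the scatter) and so did not move the number past the usual scatter. Among these three rings, the 3,5-dichlorophenyl of compound 2 therefore stands apart, with steps to both other compounds beyond the scatter, while compound 1 and compound 3 cannot be told apart. No measurement here explains why this ring differs from the other two. Still open, as far as these compounds go, is how a 3,5-difluorophenyl or 3,5-dimethylphenyl ring would compare, and whether a ring carrying an amine or a carboxylic acid on the sulfonyl sulfur would fit this picture at all.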